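The source may hold more compounds than are shown below. What is called first, only, known or untested is meant among the compounds shown, and "the series" means these compounds.

Working notes on the series. In a functional assay on NPC-TW01 cells (Homo sapiens) for inhibition, read by MTT assay, with a stated time of 72 h (a higher number here means a weaker inhibitor of growth, a lower number a stronger inhibitor of growth), compound 3 `COC(=O)c1nc(C2CCCCC2)n(-c2ccc(F)cc2)n1` gives 30500 nM, the highest of the three numbers; compound 1 `COC(=O)c1nc(C)n(-c2ccc(F)cc2)n1` gives 15200 nM and compound 2 `COC(=O)c1nc(C2CCCC2)n(-c2ccc(F)cc2)n1` gives 10400 nM. The change to compound 4 `COC(=O)c1nc(-c2ccoc2)n(-c2ccc(F)cc2)n1` is furan-3-yl in place of cyclohexyl on an aromatic carbon. Among the compounds with values here, two measured steps touch the same position: a 2.0-fold higher number from compound 1 to compound 3 (0.30 log units; within the scatter) and a 2.9-fold higher number from compound 2 to compound 3 (0.47 log units; beyond the scatter), so cyclohexyl at this carbon has given the highest number against either smaller group. Furan-3-yl is again a smaller group, so a step back toward lower numbers is expected in this assay, modest in size and possibly within the scatter, because a 2.9-fold higher number from compound 2 to compound 3 (0.47 log units; beyond the scatter) is the only step there that was beyond it. Compound 4 is estimated at 15000 nM, with a range of 5000 nM to 45000 nM. The expected step is a 2.0-fold lower number from compound 3 to compound 4 (0.31 log units; beyond the scatter).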

Compound 4, concentration for 50% growth inhibition: 11700 nM
The estimate for compound 4 lay 1.3-fold (0.11 log units) above the measured number; measured number inside the range.
By their numbers in this assay, from the lowest: compounds 2, 4, 1 and 3 (each within the scatter of the next, the first and the last beyond it).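

At this carbon, an aromatic ring carrying oxygen brings the number back from the cyclohexyl level in this assay, with a 2.6-fold lower number from compound 3 to compound 4 (0.42 log units; beyond the scatter). Against the other two groups furan-3-yl makes no readable difference, with a 1.1-fold higher number from compound 2 to compound 4 (0.05 log units; within the scatter) and a 1.3-fold lower number from compound 1 to compound 4 (0.11 log units; within the scatter), so methyl, cyclopentyl and furan-3-yl cannot be told apart in this set. Nothing at hand accounts for the gap between cyclohexyl and furan-3-yl.

Open, from the compounds shown here alone, is whether a phenyl ring, an amine or a carboxylic acid at this carbon would take the number clearly lower than compound 2 gives. Also open, going by these compounds, is whether the ring oxygen of furan-3-yl matters at all.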